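Dipropylamide Variant of Compound 1 in the Diamide Series

The compounds below may be only part of what the source reports. "The series", "measured", "known", "first", "only" and "open" are said of these compounds alone.

Among the measured compounds shown here, compound 1 `CC(C)CNC(=O)c1[nH]cnc1C(=O)Nc1ccc(Cl)c(Cl)c1` stands at the top of the three numbers so far: in a functional assay on HL-60 cells (Homo sapiens), with a stated time of 2 days (on this read-out higher numbers stand for weaker inhibition and lower numbers for stronger inhibition), compound 1 gives 14700 nM. Compound 2 `O=C(NCc1ccccc1)c1nc[nH]c1C(=O)Nc1ccc(Cl)c(Cl)c1` gives 11500 nM and compound 3 `C[C@@H](NC(=O)c1[nH]cnc1C(=O)Nc1cccc(Cl)c1)C(=O)OC(C)(C)C` gives 8200 nM in this assay, and both gaps to compound 1 lie within the usual scatter, so the three sit together as weak inhibitors.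

Compound 4 `CCCN(CCC)C(=O)c1[nH]cnc1C(=O)Nc1ccc(Cl)c(Cl)c1` differs from compound 1 by one change: dipropylamino in place of isobutylamino on a carbonyl carbon. For the measured compounds named here, no pair of measured compounds isolates this change, so nothing here calibrates it. The expectation is a step of a 1.2-fold higher number from compound 1 to compound 4 (0.09 log units; within the scatter) of small size, toward a somewhat higher number, not clearly beyond the scatter. Compound 4 is therefore estimated at 18000 nM in this assay, with a range of 6000 nM to 50000 nM.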

Compound 4, half-maximal inhibitory concentration: 379000 nM
For compound 4 the middle estimate is 21-fold (1.32 log units) below the measured one; the whole stated range lies below it.
By their numbers in this assay, from the lowest: compounds 3, 2 and 1 (each within the scatter of the next); then compound 4.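

On this carbonyl carbon, the amide group is not freely exchangeable: in this assay, dipropylamino in place of isobutylamino gives a 26-fold higher number from compound 1 to compound 4 (1.41 log units; beyond the scatter). The change removes the one hydrogen-bond donor of the leaving group and also brings more heavy atoms, so two differences travel together. Nothing available bears on the cause of this step.

Which of the two differences carries the step stays open. A propylamino group, which keeps the amide hydrogen, or a dimethylamino group, which lacks it, would help separate them.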